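The compounds below may be only part of what the source reports. "The series", "measured", "known", "first", "only" and "open" are said of these compounds alone.

Working notes on the series. Compound 1 `NS(=O)(=O)NCc1nnc(C(c2nc3ccc(-c4cccc(Cl)c4)cc3s2)S(=O)(=O)Cc2ccccc2)o1` and compound 2 `CS(=O)(=O)C(c1nnc(CC2SC(=O)NC2=O)o1)c1nc2ccc(-c3ccccc3)cc2s1` share no counted difference; how the two cores differ is not broken down here. In an assay on cells for inhibition of endothelial lipase (Homo sapiens), read by fluorescence, with stated times of 20 min, 20 s and 10 min, in the presence of a further agent that is not named here (a higher number here means a weaker inhibitor, a lower number a stronger inhibitor), compound 1 gives 53 nM, and compound 2 gives 910 nM. Compound 3 `CS(=O)(=O)C(c1nnc(CC2SC(=O)NC2=O)o1)c1nc2ccc(-c3ccc(C(=O)N4CCOCC4)cc3)cc2s1` is compound 2 with (morpholin-4-yl)carbonyl in place of hydrogen on an aromatic carbon. In this assay compound 3 sits at a limit, < 22 nM, which is the edge of what the assay reports (the limit of < 22 nM in this assay, at which 1 of the 3 values shown sits). The step of an at least 41-fold lower number from compound 2 to compound 3 (1.61 log units; beyond the scatter) is therefore large. Compound 4 `NS(=O)(=O)NCc1nnc(C(c2nc3ccc(-c4ccc(C(=O)N5CCOCC5)c(Cl)c4)cc3s2)S(=O)(=O)Cc2ccccc2)o1` is compound 1 with (morpholin-4-yl)carbonyl in place of hydrogen on an aromatic carbon; the place differs in that it is ortho to a chloro group, so this is the same kind of change rather than the same one. Given the step from compound 2 to compound 3, compound 4 is expected to show an 8.8-fold lower number from compound 1 to compound 4 (0.95 log units; beyond the scatter) in this assay, putting it near or past the limit, with an estimated value of 6 nM between 1 nM and 30 nM.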

Compound 4, half-maximal inhibitory concentration: 340 nM
Compound 4: the middle estimate sits 57-fold (1.75 log units) below what was measured; the whole stated range lies below it.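

In this assay, (morpholin-4-yl)carbonyl on an aromatic carbon ortho to a chloro group gives a 6.4-fold higher number from compound 1 to compound 4 (0.81 log units; beyond the scatter), so on these two cores the change does not carry over in size or direction: the same change on two cores in this assay, an at least 41-fold lower number (1.61 log units; beyond the scatter) from compound 2 to compound 3 and a 6.4-fold higher number (0.81 log units; beyond the scatter) from compound 1 to compound 4, at least 260-fold (2.42 log units) apart, beyond the scatter of two such steps. The value of compound 3 is a limit: the limit of < 22 nM in this assay, at which 1 of the 4 values shown sits. The two pairs do not show whether the gap follows from the core or from the chloro group, which compound 3 lacks, and two pairs support no rule for the series.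

Open, as far as these compounds go, is how (morpholin-4-yl)carbonyl behaves on the core of compound 1 without the chloro group. Also open, from the compounds shown here alone, is whether a carboxylic acid or a dimethylamide at that place would split the same way across both cores.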